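This account rests on a few compounds, and the source may have more. Where it says the series, first, only, none or still open, it means among the compounds named here.

Working notes on the series. The shared core of compound 1 `CCOC(=O)c1cc(C#Cc2ccc(N)cc2)c2cc(OC)ccc2n1` carries two ring systems on the ester-bearing core; compound 2 `CCOC(=O)c1cc([Se]c2ccccc2)c2cc(C)ccc2n1` and compound 3 `CCOC(=O)c1cc([Se]c2ccc3cc(OC)ccc3c2)c2cc(OC)ccc2n1` keep the core and differ in the group on the ring. All three have been measured in a functional assay on SK-MEL-147 cells (Homo sapiens) for cytotoxicity, read by MTT assay, with a stated time of 24 h; a higher number here means that more compound is needed for the effect, a lower number that less compound is needed. In this assay compound 1 gives 8800 nM, the lowest of the three numbers. Compound 2 gives 12000 nM, which lies within the scatter of compound 1, so the two cannot be told apart. Among the measured compounds shown here, compound 3 gives 30800 nM, a higher number than compound 1 by a margin beyond the scatter; with no single-point step between them, only the two values can be compared.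

Compound 4 `CCOC(=O)c1cc(C#Cc2ccccc2[N+](=O)[O-])c2cc(OC)ccc2n1` has not been measured. It differs from compound 1 as follows: 2-nitrophenyl in place of 4-aminophenyl on a triple-bonded carbon. For the measured compounds named here, no measured pair shows this change, so its effect in this assay is unknown. The step from compound 1 to compound 4 is expected to be small, a 1.4-fold higher number from compound 1 to compound 4 (0.13 log units; within the scatter), with no clear direction beyond the scatter. For compound 4 the estimate in this assay is 12000 nM, with a range from 4000 nM to 36000 nM.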

Compound 4, half-maximal effective concentration: > 150000 nM
Compound 4 was reported as a limit; the forecaster's own chance of this, stated with the estimate: 10%; middle value at least 12-fold (1.09 log units) from the limit.
By their numbers in this assay, from the lowest: compounds 1 and 2 (each within the scatter of the next); then compound 3. At a limit, above all of these: compound 4.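

The pair gives the series its first one-place comparison, and it shows that the ring on the triple-bonded carbon can strongly shift the read-out in this assay: 2-nitrophenyl in place of 4-aminophenyl gives an at least 17-fold higher number from compound 1 to compound 4 (1.23 log units; beyond the scatter). Compound 4 gives > 150000 nM, which is a limit of the assay and not a number. The true size of the step therefore cannot be read, and the result sits at the end of the measurable range: the limit of > 150000 nM in this assay, at which 1 of the 4 values shown sits.

Going by these compounds, whether the step belongs to the arrival of the nitro group or to the departure of the amine stays open, and a plain phenyl on the triple-bonded carbon would help to separate the two. The ester is the same in all compounds shown, so the effect of a carboxylic acid in its place is also open.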